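A cyclopropyl amide exchanged for a benzamide on a shared core

This account rests on a few compounds, and the source may have more. Where it says the series, first, only, none or still open, it means among the compounds named here.

Compound 2 `N#CC1=C(NC(=O)C2CC2)N(c2ccc(S(N)(=O)=O)cc2)C2=C(C(=O)CCC2)C1c1ccc(Cl)cc1Cl` carries a cyclopropyl group on its amide carbonyl carbon. For the measured compounds named here, in a functional assay on Ehrlich cells (Mus musculus) for cytotoxicity, read by trypan blue exclusion, with a stated time of 2 h, tested at 50 ug/mL (a higher number here means a stronger effect of the compound at the concentration tested, a lower number a weaker effect), compound 2 gives 40%, the lower of the two numbers measured so far; its nearest neighbour is compound 1 `CC(Cl)CC(=O)NC1=C(C#N)C(c2ccc(Cl)cc2Cl)C2=C(CCCC2=O)N1c1ccc(S(N)(=O)=O)cc1`, which in this assay gives 55%. Going by the values given here, the only measured step, a number 15 percentage points lower from compound 1 to compound 2 (beyond the scatter), put cyclopropyl in place of 2-chloropropyl on a carbonyl carbon and lowered the read-out by a modest amount.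

Compound 3 `N#CC1=C(NC(=O)c2ccccc2)N(c2ccc(S(N)(=O)=O)cc2)C2=C(C(=O)CCC2)C1c1ccc(Cl)cc1Cl` differs from compound 2 in one place: phenyl in place of cyclopropyl on a carbonyl carbon. Among the compounds with values here, no measured step exchanges cyclopropyl for phenyl, so the single step available bears on it only by showing that a change of the group on the carbonyl carbon moves the read-out modestly; it gives no direction for the present exchange. Compound 3 is therefore expected to show a step of a number 5 percentage points higher from compound 2 to compound 3 (within the scatter), which may well stay within the scatter. The estimate for compound 3 in this assay is 45%, with a range from 25% to 65%.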

Compound 3, a percentage reported as activity, at one concentration (the size of the read-out at that concentration, not a potency): 70%
The estimate for compound 3 lay 25 percentage points below the measured number; the whole stated range lies below it.
By their numbers in this assay, from the lowest: compound 2; then compound 1; then compound 3.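

In this assay, for the compounds shown here, the exchange of cyclopropyl for phenyl on the carbonyl carbon gives a number 30 percentage points higher from compound 2 to compound 3 (beyond the scatter), which shows that a change at this position can raise the read-out as well as lower it, whereas the one earlier step showed only a fall. Phenyl also compares favourably with the open chain, with a number 15 percentage points higher from compound 1 to compound 3 (beyond the scatter), so compound 3 now stands highest of the three, and the group on the carbonyl carbon sets the order among them. A ring at this place does not by itself give a high number, since compound 2, with its three-membered ring, stands lowest and compound 3, with its six-membered aromatic ring, stands highest. Nothing in the available data accounts for this order.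

The compounds shown leave open whether the gain belongs to phenyl alone or would hold for a pyridine ring, a methoxy-bearing phenyl ring or a longer carbon chain on the same carbonyl carbon. On these data alone, each number is also a single read-out at one concentration, so how the three compounds would compare across a range of concentrations remains open.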